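Amide nitrogen substituents on the shared core

The source may report more compounds than this note shows. Statements on the series, on what has been measured and on what is new or still open speak of the compounds shown alone.

Measured so far:
Compound 1 `Nc1sc(-c2ccc(Cl)cc2)c(-c2ccc(Cl)cc2)c1C(=O)NC1CCC1`: 12500 nM
Compound 2 `CC(C)CNC(=O)c1c(N)sc(-c2ccc(Cl)cc2)c1-c1ccc(Cl)cc1`: 21000 nM

In a functional assay on A549 cells (Homo sapiens) for inhibition, read by sulforhodamine B assay, with a stated time of 72 h (on this read-out lower numbers stand for stronger inhibition and higher numbers for weaker inhibition), compound 1 gives 12500 nM. Its only neighbour in the set is compound 2, reached by a 1.7-fold higher number from compound 1 to compound 2 (0.23 log units; within the scatter), so the two numbers cannot be told apart and compound 1 holds no distinct position on the numbers shown. Compound 3 `Nc1sc(-c2ccc(Cl)cc2)c(-c2ccc(Cl)cc2)c1C(=O)NCc1ccccc1` carries the change (benzyl in place of cyclobutyl on an amide-type nitrogen). Among the measured compounds shown here, the single step that bears on it is the one on the same amide-type nitrogen, cyclobutyl to isobutyl, which stayed inside the scatter. Benzyl brings an aromatic ring that neither compound 1 nor compound 2 holds, so the step has no direct precedent, but on the one comparison available the expectation in this assay is a step no larger than the scatter, with the direction open. The estimate for compound 3 is 12000 nM, range 5000 nM to 30000 nM, meaning an expected step of a 1.0-fold lower number from compound 1 to compound 3 (0.02 log units; within the scatter).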

Compound 3, half-maximal inhibitory concentration: 16300 nM
Compound 3: the middle estimate sits 1.4-fold (0.13 log units) below what was measured; measured number inside the range.
By their numbers in this assay, from the lowest: compounds 1, 3 and 2 (each within the scatter of the next).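

In this assay, benzyl on the amide-type nitrogen brings a six-membered aromatic ring to this position, and the change gives a 1.3-fold higher number from compound 1 to compound 3 (0.12 log units; within the scatter) and, against the isobutyl amide, a 1.3-fold lower number from compound 2 to compound 3 (0.11 log units; within the scatter). Cyclobutyl, isobutyl and benzyl therefore cannot be told apart on this read-out, so on these three compounds an aromatic ring at this position reads no differently from the two non-aromatic groups. No measured evidence bears on this result.

Open, on these data alone, is whether an amine or a carboxylic acid on the benzyl ring, or a longer chain on the amide-type nitrogen, would carry the number beyond the scatter. Also open, as far as these compounds go, is how much of the number rests on the shared core, which is the same in all three compounds.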